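A few compounds are considered here, and "the series" means these few. Any claim that something is new, unique, unknown or untested is made for them only; others in the source may bear on it.

Values from a functional assay on DU-145 cells (Homo sapiens) for inhibition, read by trypan blue exclusion, with a stated time of 96 h; on this read-out lower numbers stand for stronger inhibition of growth and higher numbers for weaker inhibition of growth
- compound 1 `Cc1ccc(S(=O)(=O)/C(=C/c2ccc(C)s2)C(=O)c2ccc(Br)cc2)cc1` gives 25000 nM
- compound 2 `Cc1ccc(S(=O)(=O)/C(=C/c2c(O)cc(O)cc2O)C(=O)c2ccc(Br)cc2)cc1` gives > 100000 nM as a limit of the assay
- compound 3 `CSc1ccc(/C=C(\C(=O)c2ccc(Br)cc2)S(=O)(=O)Cc2ccc(C)cc2)cc1` gives 10000 nM

Compound 3 at 10000 nM holds the lowest number shown, and compound 1 lies nearest at 25000 nM on the weaker side. Compound 4 `CSc1ccc(/C=C(\C(=O)c2ccc(Br)cc2)S(=O)(=O)c2ccc(C)cc2)cc1` is still unmeasured and carries one change: 4-methylphenyl in place of 4-methylbenzyl on a sulfonyl sulfur with 4-methylphenyl in place of 4-methylbenzyl on a sulfonyl sulfur. For the measured compounds named here, the only measured step of an at least 4.0-fold higher number from compound 1 to compound 2 (0.60 log units; beyond the scatter) lies elsewhere in the molecule and gives no size for this change. The expected outcome in this assay is therefore no shift beyond the scatter, with a 1.2-fold higher number from compound 3 to compound 4 (0.08 log units; within the scatter) as the estimated step. For compound 4 the estimate is 12000 nM with an expected range from 3000 nM to 50000 nM in this assay.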

Compound 4, concentration for 50% growth inhibition: 1000 nM
For compound 4 the middle estimate is 12-fold (1.08 log units) above the measured one, and the stated range ends above it.
By their numbers in this assay, from the lowest: compound 4; then compound 3; then compound 1. At a limit, above all of these: compound 2.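

In this assay, for the compounds shown here, the sulfonyl sulfur is a sensitive position: 4-methylphenyl in place of 4-methylbenzyl gives a 10-fold lower number from compound 3 to compound 4 (1.00 log units; beyond the scatter), a size the earlier compounds did not give. With 4-(methylsulfanyl)phenyl on the double-bonded chain carbon, the comparison with the 5-methylthiophen-2-yl compound reads a 25-fold lower number from compound 1 to compound 4 (1.40 log units; beyond the scatter). The comparison with the 2,4,6-trihydroxyphenyl compound reads an at least 100-fold lower number from compound 2 to compound 4 (2.00 log units; beyond the scatter), and it rests on a limit of the assay rather than a number: the limit of > 100000 nM in this assay, at which 1 of the 4 values shown sits.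

Still open, as far as these compounds go, is how an amine or a carboxylic acid in place of 4-methylphenyl on the sulfonyl sulfur would read. The compounds shown also give no cause for the step.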